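Thiazolyl sulfone replacing hydroxyphenyl sulfone in compound 4

This account rests on a few compounds, and the source may have more. Where it says the series, first, only, none or still open, it means among the compounds named here.

Three analogues of the shared core carry measured numbers in a functional assay (Cavia porcellus) with sulfonylurea receptors; K-ATP channels (Homo sapiens) as the target; on this read-out lower numbers stand for stronger inhibition and higher numbers for weaker inhibition. Compound 1 `CC(O)(C(=O)Nc1ccc(C#N)c(S(=O)(=O)c2ccccc2)c1)C(F)(F)F` gives 2600 nM in this assay. Compound 2 `CC(O)(C(=O)Nc1ccc(S(=O)(=O)c2ccccc2O)cc1)C(F)(F)F` gives 3090 nM in this assay, the higher of the two numbers, though the gap to compound 1 lies within the scatter, so the two cannot be ordered. Compound 3 `CC(O)(C(=O)Nc1ccc(C(=O)c2cccc(Cl)c2)cc1)C(F)(F)F` is reported in this assay only as a limit, > 30000 nM, and not as a number; (the limit of > 30000 nM in this assay, at which 1 of the 3 values shown sits).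

Compound 4 `CC(O)(C(=O)Nc1ccc(S(=O)(=O)c2cncs2)cc1)C(F)(F)F` is not yet measured. It differs from compound 2 in one place: 1,3-thiazol-5-yl in place of 2-hydroxyphenyl on a sulfonyl sulfur. The sulfonyl link to the shared core is kept. Among the measured compounds shown here, no measured pair in this set isolates a change on the sulfonyl aryl group, so the size of the step is open; a step of modest size, toward a somewhat higher number, is expected, a 1.5-fold higher number from compound 2 to compound 4 (0.16 log units; within the scatter), and a result within the scatter of compound 2 would not surprise. Compound 4 is therefore estimated at 4500 nM in this assay, with a range from 1400 nM to 15000 nM.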

Compound 4, half-maximal inhibitory concentration: 7700 nM
For compound 4 the middle estimate is 1.7-fold (0.23 log units) below the measured one; the range from low to high includes it.
By their numbers in this assay, from the lowest: compounds 1 and 2 (each within the scatter of the next); then compound 4. At a limit, above all of these: compound 3.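

In this assay the group on the sulfonyl sulfur now has its first single-place step, 1,3-thiazol-5-yl in place of 2-hydroxyphenyl: a 2.5-fold higher number from compound 2 to compound 4 (0.40 log units; beyond the scatter). This position therefore responds to the change of aryl group, though the step is modest and compound 4 still reads as a number, not as a limit. Nothing measured in this set accounts for the step.

It stays open whether the step follows the loss of the hydroxyl or the change of ring, as no single-place pair shown separates the two. Going by these compounds, how an aminophenyl or a pyridinyl group on the sulfonyl sulfur would read in this assay also remains open.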